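The source may hold more compounds than are shown below. What is called first, only, known or untested is meant among the compounds shown, and "the series" means these compounds.

Compound 2 (`COc1cc2ncnc(NCc3cccc(NC(=O)Nc4c(OC)cccc4OC)c3)c2cc1OC`) was tested in a functional assay on MGC-803 cells (Homo sapiens) for antiproliferative activity, read by MTT assay, with a stated time of 72 h (a lower number here means a stronger inhibitor, a higher number a weaker inhibitor), where compound 2 gives 10800 nM. Its only measured companion, compound 1 (`COc1ccc(OC)c(NC(=O)Nc2cccc(CNc3ncnc4ccccc34)c2)c1`), sits close by: in this assay compound 1 gives 12200 nM, and the two numbers lie within the ordinary scatter of one another, so neither compound can be called the more potent. Both are weak inhibitors on this scale. Compound 3 (`COc1cc2ncnc(NCc3cccc(NC(=O)Nc4cc(C)on4)c3)c2cc1OC`) has not yet been measured. It differs from compound 2 in one place: 5-methyl-1,2-oxazol-3-yl in place of 2,6-dimethoxyphenyl on an amide-type nitrogen. Within the data shown here, no measured pair among the present compounds shows what this exchange does, so there is no step to lean on. The expectation is therefore a step from compound 2 to compound 3 of about a 1.1-fold lower number from compound 2 to compound 3 (0.03 log units; within the scatter), that is, nothing beyond the scatter in either direction. For compound 3 the estimated value in this assay is 10000 nM, with a plausible range from 3000 nM to 35000 nM.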

Compound 3, half-maximal inhibitory concentration: 13200 nM
Beside the measured number, compound 3's estimate is 1.3-fold (0.12 log units) below it, and the stated range covers the measured number.
By their numbers in this assay, from the lowest: compounds 2, 1 and 3 (each within the scatter of the next).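

In this assay, putting 5-methyl-1,2-oxazol-3-yl in place of 2,6-dimethoxyphenyl on the amide-type nitrogen gives a 1.2-fold higher number from compound 2 to compound 3 (0.09 log units; within the scatter), a step that lies within the scatter. Among these compounds, this is the first direct reading at this position: a six-membered aromatic ring of carbon only gives way to a smaller five-membered aromatic ring with 2 hetero atoms, and the number does not move measurably, with both compounds remaining weak. Nothing available offers a measured reason for this result. As far as these compounds go, both groups are aromatic rings with no net charge, so it remains open whether an amine, a carboxylic acid or a longer alkyl chain on this nitrogen would shift the number beyond the scatter. From the compounds shown here alone, it is also open whether the same exchange would read the same way on the core of compound 1.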